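Stripping the aryl group from an amidine nitrogen

The source may hold more compounds than are shown below. What is called first, only, known or untested is meant among the compounds shown, and "the series" means these compounds.

Compound 1 `Cc1ccc(S(=O)(=O)/N=C(/CCNC2=CC(=O)c3ccccc3C2=O)Nc2cccc(C)c2)cc1` carries a 3-methylphenyl group on an amine nitrogen of the shared core. Among the measured compounds shown here, in a functional assay on HeLa cells (Homo sapiens) for cytotoxicity, read by MTT assay, with a stated time of 48 h (on this read-out lower numbers stand for stronger inhibition and higher numbers for weaker inhibition), compound 1 gives 9060 nM, which places it second highest of the three numbers measured so far. Compound 2 `Cc1ccc(S(=O)(=O)/N=C(/CCNC2=CC(=O)c3ccccc3C2=O)Nc2ccc(Cl)cc2Cl)cc1` has 2,4-dichlorophenyl at that place, and in this assay compound 2 gives 20500 nM; the step is a 2.3-fold higher number from compound 1 to compound 2 (0.35 log units; beyond the scatter). Compound 3 `Cc1ccc(S(=O)(=O)/N=C(/CCNC2=CC(=O)c3ccccc3C2=O)NCc2ccccc2)cc1` has benzyl there, and in this assay compound 3 gives 3980 nM; the step is a 2.3-fold lower number from compound 1 to compound 3 (0.36 log units; beyond the scatter). Compound 4 `Cc1ccc(S(=O)(=O)/N=C(\N)CCNC2=CC(=O)c3ccccc3C2=O)cc1` has not been measured; the change from compound 1 is hydrogen in place of 3-methylphenyl on an amine nitrogen. For the measured compounds named here, no measured step removes the aryl group altogether, so the two swaps of one group for another are the only guide, and they moved the number modestly in opposite directions. Because a 2.3-fold higher number from compound 1 to compound 2 (0.35 log units; beyond the scatter) and a 2.3-fold lower number from compound 1 to compound 3 (0.36 log units; beyond the scatter) both stay modest, a modest step is expected here too, with the direction uncertain; a small loss is estimated, a 1.5-fold higher number from compound 1 to compound 4 (0.19 log units; within the scatter). Compound 4 is therefore expected to give about 14000 nM, within a range from 4500 nM to 45000 nM.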

Compound 4, half-maximal inhibitory concentration: 24600 nM
Estimate against measurement, compound 4: 1.8-fold (0.24 log units) below; the range from low to high includes it.
By their numbers in this assay, from the lowest: compound 3; then compound 1; then compounds 2 and 4 (each within the scatter of the next).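

Taking the aryl group away altogether does not leave the number unchanged in this assay: the step is a 2.7-fold higher number from compound 1 to compound 4 (0.43 log units; beyond the scatter) and, measured against the benzyl group, a 6.2-fold higher number from compound 3 to compound 4 (0.79 log units; beyond the scatter) on the same nitrogen. The step of a 1.2-fold higher number from compound 2 to compound 4 (0.08 log units; within the scatter) adds something the earlier swaps could not show, since the 2,4-dichlorophenyl group gives no measurable gain over plain hydrogen, so among these four compounds only 3-methylphenyl and benzyl bring the number down, and compound 2 goes against any rule that a larger group here helps. No measurement given here explains this difference between the groups.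

Open, from the compounds shown here alone, is whether a small group such as methyl would behave like hydrogen or like benzyl. Also open, going by these compounds, is how a longer chain such as 2-phenylethyl or an unsubstituted phenyl group would fare at this nitrogen.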